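A few compounds are considered here, and "the series" means these few. Any claim that something is new, unique, unknown or untested is made for them only; others in the source may bear on it.

Compound 1 `Cc1cc2nc(-c3nccs3)n(-c3ccc4c(N)nc(N)nc4c3)c2cc1C` gives 93 nM in an assay on isolated protein for inhibition of Dihydrofolate reductase (Homo sapiens), read by spectrophotometry, using NADPH, with a stated time of 10 min; on this read-out lower numbers stand for stronger inhibition and higher numbers for weaker inhibition. Compound 2 `Cc1cc2nc(-c3ccco3)n(-c3ccc4c(N)nc(N)nc4c3)c2cc1C` gives 943 nM in this assay. Compound 3 `Cc1cc2nc(C3CC3)n(-c3ccc4c(N)nc(N)nc4c3)c2cc1C` gives 1160 nM in this assay.

Among these three numbers, compound 2 stands second highest. Its nearest neighbour is compound 3, reached by a 1.2-fold higher number from compound 2 to compound 3 (0.09 log units; within the scatter), a step that stays within the scatter; its furthest is compound 1, separated from it by a 10-fold higher number from compound 1 to compound 2 (1.01 log units; beyond the scatter).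

Compound 4 `Cc1cc2nc(C3CCOC3)n(-c3ccc4c(N)nc(N)nc4c3)c2cc1C` has not been measured in this assay. It differs from compound 2 in one place: oxolan-3-yl in place of furan-2-yl on an aromatic carbon. Within the data shown here, two measured steps bear on this change. The step of a 10-fold higher number from compound 1 to compound 2 (1.01 log units; beyond the scatter) shows that exchanging one five-membered aromatic ring for another can move the number a great deal. The step of a 1.2-fold higher number from compound 2 to compound 3 (0.09 log units; within the scatter), in which furan-2-yl gives way to a non-aromatic group, stays within the scatter. The change to oxolan-3-yl likewise replaces the aromatic ring with a non-aromatic one, so the second step is the closer guide. Compound 4 is therefore expected to show a 1.3-fold higher number from compound 2 to compound 4 (0.10 log units; within the scatter), no step beyond the scatter. The estimate for compound 4 in this assay is 1200 nM, with a range from 500 nM to 3000 nM.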

Compound 4, inhibition constant: > 5000 nM
Compound 4: a limit, no number; the forecaster's own chance of this, stated with the estimate: 5%; at least 4.1-fold (0.61 log units) between middle value and limit.
By their numbers in this assay, from the lowest: compound 1; then compounds 2 and 3 (each within the scatter of the next). At a limit, above all of these: compound 4.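

In this assay compound 4 stands at a limit of the assay and has no number: the limit of > 5000 nM in this assay, at which 1 of the 4 values shown sits. Even read from that limit, the step of an at least 5.3-fold higher number from compound 2 to compound 4 (0.72 log units; beyond the scatter) shows that this position, the aromatic carbon between two ring nitrogen atoms, does not accept every non-aromatic ring as the earlier step of a 1.2-fold higher number from compound 2 to compound 3 (0.09 log units; within the scatter) suggested, although furan-2-yl and oxolan-3-yl match in heavy atoms, hydrogen-bond donors and acceptors; the change from a five-membered aromatic ring to a five-membered non-aromatic one is enough to carry the number beyond the scatter. Loss of the aromatic ring cannot be the whole story, since cyclopropyl is also non-aromatic and the step of an at least 4.3-fold higher number from compound 3 to compound 4 (0.63 log units; beyond the scatter) still lies beyond the scatter, while an at least 53-fold higher number from compound 1 to compound 4 (1.73 log units; beyond the scatter) gives the widest gap yet seen at this position.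

Going by these compounds, how far compound 4 really lies past its limit stays unknown, so each of these steps gives only a lower bound on the true size of the change. The compounds shown also leave open how an amine such as pyrrolidin-3-yl, a six-membered ring such as pyridin-2-yl or an open methoxyethyl chain would behave at this position.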